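This account rests on a few compounds, and the source may have more. Where it says the series, first, only, none or still open, it means among the compounds named here.

Measured compounds:
Compound 1 `C=C(C)C(=O)NC(=O)NC1=CS(=O)(=O)O[C@@]12[C@@H](CO[Si](C)(C)C(C)(C)C)O[C@@H](n1cc(C)c(=O)n(C)c1=O)[C@@H]2O[Si](C)(C)C(C)(C)C` — in a functional assay on HEL cells (Homo sapiens) for cytotoxicity, read by microscopy (a higher number here means that more compound is tolerated, a lower number that less compound is tolerated), compound 1 gives 20000 nM.
Compound 2 `Cc1cn([C@@H]2O[C@H](CO[Si](C)(C)C(C)(C)C)[C@@]3(OS(=O)(=O)C=C3NC(=O)c3ccccc3)[C@H]2O[Si](C)(C)C(C)(C)C)c(=O)n(C)c1=O` — in this assay compound 2 gives >= 3200 nM, which is a limit of the assay and not a number.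

Compound 2 therefore stands only at a limit on the numbers shown. Among the measured compounds shown here, the one measured step, a step that the limit leaves unreadable from compound 1 to compound 2, cannot be read because of the limit of >= 3200 nM in this assay, at which 1 of the 2 values shown sits, so it gives no usable size or direction. Compound 3 `COC(=O)C(=O)CNC1=CS(=O)(=O)O[C@@]12[C@@H](CO[Si](C)(C)C(C)(C)C)O[C@@H](n1cc(C)c(=O)n(C)c1=O)[C@@H]2O[Si](C)(C)C(C)(C)C` differs from compound 2 in one place: ((methoxycarbonyl)carbonyl)methyl in place of benzoyl on an amine nitrogen. For the measured compounds named here, no measured step involves an exchange of this kind, and the single step that exists is unreadable, so there is no basis for expecting a move beyond the scatter in either direction. Compound 3 is therefore estimated to tolerate about 8000 nM, within a range of 2000 nM to 40000 nM, which means an expected step that the limit leaves unreadable from compound 2 to compound 3.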

Compound 3, minimum cytotoxic concentration: > 400000 nM
Compound 3 gave a limit, no number; the forecaster's own chance of this, stated with the estimate: 40%; middle value at least 50-fold (1.69 log units) from the limit.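

Among the compounds shown here, on the amine nitrogen of the shared core, ((methoxycarbonyl)carbonyl)methyl in place of ((1-methylethenyl)carbonyl)carbamoyl gives an at least 20-fold higher number from compound 1 to compound 3 (1.30 log units; beyond the scatter) in this assay, the first readable evidence that the group at this position can change how much compound the cells tolerate. Compound 3 gives > 400000 nM in this read-out, which is a limit and not a number, so the step has a smallest size but no known full size. The step between compound 2 and compound 3 cannot be read, as both of its values are limits.

Which part of the ((methoxycarbonyl)carbonyl)methyl group goes with the higher number remains open. A carboxylic acid in place of the methyl ester, or a plain acetyl on the same amine nitrogen, would help to separate those parts.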